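The source may report more compounds than this note shows. Statements on the series, on what has been measured and on what is new or still open speak of the compounds shown alone.

Compound 1 `Cc1ccc2nc(C)n(NC(=O)/C(C#N)=C/c3ccccc3)c(=O)c2c1`: 14000 nM in a functional assay on HepG2 cells (Homo sapiens) for cytotoxicity, read by MTT assay, with a stated time of 3 days; a lower number here means a stronger inhibitor, a higher number a weaker inhibitor.
Compound 2 `Cc1ccc2nc(C)n(NC(=O)/C(C#N)=C/c3cccc(O)c3)c(=O)c2c1`: 14000 nM in this assay.

Compound 2 stands level with compound 1 on the numbers shown: the step of no change at the digits printed from compound 1 to compound 2 (within the scatter), which put a hydroxy in place of a hydrogen on an aromatic carbon, did not move the reading beyond the scatter. Compound 3 `Cc1ccc2nc(C)n(NC(=O)/C(C#N)=C/c3ccc(O)cc3)c(=O)c2c1` has not yet been measured. It differs from compound 2 by 4-hydroxyphenyl in place of 3-hydroxyphenyl on a double-bonded chain carbon bound to a double-bonded chain carbon; the atoms are the same, only joined differently. Within the data shown here, only one measured step bears on this change, the one from compound 1 to compound 2, which introduced the same hydroxy group and left the reading unchanged. Nothing measured here shows that moving that hydroxy to another carbon of the ring matters, so no step beyond the scatter is expected in this assay for compound 3. The expected step of no change at the digits printed from compound 2 to compound 3 (within the scatter) is therefore essentially flat. Compound 3 is estimated at 14000 nM, with a range from 5000 nM to 40000 nM.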

Compound 3, half-maximal inhibitory concentration: 13000 nM
Compound 3: middle estimate off by 1.1-fold (0.03 log units), on the high side; the range from low to high includes it.
By their numbers in this assay, from the lowest: compounds 3, 1 and 2 (each within the scatter of the next).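

Moving the hydroxy, with 4-hydroxyphenyl in place of 3-hydroxyphenyl, gives a 1.1-fold lower number from compound 2 to compound 3 (0.03 log units; within the scatter) in this assay and so shows that the reading does not depend on which of these two ring carbons carries the group. Hydroxy in place of hydrogen at the new ring carbon gives a 1.1-fold lower number from compound 1 to compound 3 (0.03 log units; within the scatter) and thus matches the earlier result, so neither hydroxyphenyl compound separates from the unsubstituted phenyl compound. Nothing measured here offers an explanation for this flat result.

Still open, on these data alone, is whether a different group on this ring, such as a methoxy, an amine or a carboxylic acid, would shift the reading beyond the scatter. The compounds shown also leave open how changes elsewhere, in the nitrile or the shared core, would affect it.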